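This account rests on a few compounds, and the source may have more. Where it says the series, first, only, none or still open, it means among the compounds named here.

Measured so far in this series:
compound 1, `N#C/C(=C\c1c(-c2ccccc2)[nH]c2ccccc12)C(=O)c1cccs1`: 400 nM
compound 2, `COc1ccc2[nH]c(-c3ccccc3)c(/C=C(\C#N)S(=O)(=O)c3ccccc3)c2c1`: 1300 nM

In a functional assay on MT4 cells (Homo sapiens) for antiproliferative activity, read by MTT assay, with a stated time of 96 h (a higher number here means that more compound is needed for the effect, a lower number that less compound is needed), compound 1 gives 400 nM while compound 2 gives 1300 nM. Compound 2 stands highest of the two numbers; its nearest neighbour is compound 1, whose number in this assay is lower, and that gap lies beyond the scatter. Among the compounds with values here, the two compounds differ in more than one place, so no single-change step between measured compounds exists to read off.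

Compound 3, `N#C/C(=C\c1c(-c2ccccc2)[nH]c2ccccc12)S(=O)(=O)c1ccccc1`, is still to be measured in this assay. It arises from compound 2 by hydrogen in place of methoxy on an aromatic carbon. Compound 1 also lacks the methoxy but carries a different group on the exocyclic chain, so its lower number cannot be credited to the methoxy alone. The expectation leans toward a lower number for compound 3 because compound 1 gives 400 nM without a methoxy, but the step is taken as modest and may fall within the scatter. The step expected is a 1.9-fold lower number from compound 2 to compound 3 (0.27 log units; within the scatter). Compound 3 is estimated at 700 nM in this assay, with a range from 250 nM to 2000 nM.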

Compound 3, half-maximal effective concentration: 400 nM
For compound 3 the middle estimate is 1.8-fold (0.24 log units) above the measured one, within the range that was stated.
By their numbers in this assay, from the lowest: compounds 1 and 3 (each within the scatter of the next); then compound 2.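

In this assay, within the data shown here, the ring position that is meta to a fused ring and para to a fused ring proves sensitive to substitution: hydrogen in place of methoxy gives a 3.3-fold lower number from compound 2 to compound 3 (0.51 log units; beyond the scatter) in the one pair that isolates this change, with phenylsulfonyl on the chain in both compounds. On the chain, phenylsulfonyl in place of (thiophen-2-yl)carbonyl gives no change at the digits printed from compound 1 to compound 3 (within the scatter) when hydrogen occupies the ring position, so of the two single-place steps now available, only the methoxy step lies beyond the scatter. No measurement at hand bears on the reason for either result.

On these data alone, the methoxy step rests on a single pair, so it remains open whether it would carry over to the compounds with (thiophen-2-yl)carbonyl on the chain. It is also unknown how a fluorine atom, a hydroxyl group or a longer alkoxy chain at this ring position would compare with hydrogen and methoxy, or whether an amine or a carboxylic acid on the chain would keep the number seen with the two chain groups so far.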